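A Smaller Aryl Group on the Isoxazole of Compound 2

The source may report more compounds than this note shows. Statements on the series, on what has been measured and on what is new or still open speak of the compounds shown alone.

Of the compounds shown here, two sharing a benzothiazole-bearing core have been measured in a functional assay on MCF7 cells (Homo sapiens) for antiproliferative activity, read by MTT assay; a higher number here means a weaker inhibitor, a lower number a stronger inhibitor. Compound 1 `COc1ccc2nc(N(Cc3cc(-c4ccc(Br)cc4)no3)c3nc4ccc(F)cc4s3)sc2c1` gives 41200 nM in this assay. Compound 2 `FC(F)(F)Sc1ccc(-c2cc(CN(c3ncccn3)c3nc4ccccc4s3)on2)cc1` gives 17200 nM in this assay, the lower of the two numbers, and its gap to compound 1 lies beyond the usual scatter.

Compound 3 `Fc1ccccc1-c1cc(CN(c2ncccn2)c2nc3ccccc3s2)on1` has not yet been measured. It differs from compound 2 in one place: 2-fluorophenyl in place of 4-((trifluoromethyl)sulfanyl)phenyl on an aromatic carbon. Going by the values given here, no measured pair tracks this change, so its effect can only be guessed. The two measured values give no hint that the aryl group at this position carries much of the activity, and the new group is the smaller one. Compound 3 is therefore expected to land near compound 2 or somewhat weaker, with a 1.5-fold higher number from compound 2 to compound 3 (0.18 log units; within the scatter) expected as the step in this assay. The estimate for compound 3 is 26000 nM, in a range from 8000 nM to 85000 nM.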

Compound 3, half-maximal inhibitory concentration: 19500 nM
Beside the measured number, compound 3's estimate is 1.3-fold (0.12 log units) above it; measured number inside the range.
By their numbers in this assay, from the lowest: compounds 2 and 3 (each within the scatter of the next); then compound 1.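

In this assay, putting 2-fluorophenyl in place of 4-((trifluoromethyl)sulfanyl)phenyl on the aromatic carbon next to the ring nitrogen gives a 1.1-fold higher number from compound 2 to compound 3 (0.05 log units; within the scatter). At this position, then, the aryl group can go from 11 heavy atoms to 7 and lose its sulfur and all but one of its fluorines with no change beyond the scatter, so this particular para-free swap leaves the read-out where it was. Nothing in the data at hand accounts for this result.

Still open, as far as these compounds go, is whether the same holds for groups of another kind on this carbon, such as a phenyl ring bearing an amine or a carboxylic acid, or a plain methyl. Also open, from the compounds shown here alone, is whether the step carries over to the core of compound 1, which differs from compound 2 in more than one place.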